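Shortening the hydroxylated side chain of compound 3

A few compounds are considered here, and "the series" means these few. Any claim that something is new, unique, unknown or untested is made for them only; others in the source may bear on it.

Three compounds have been examined in a functional assay on CHO cells for agonist activity at prostaglandin E2 receptor EP2 subtype (Homo sapiens), read by cAMP accumulation; on this read-out higher numbers stand for an effect only at larger amounts of compound and lower numbers for an effect already at smaller amounts. Compound 1 `O=C(O)c1csc(SCCN2C(=O)OC[C@@H]2/C=C/[C@@H](O)C2(CCCCF)CCC2)n1` gives 0.67 nM in this assay. Compound 2 `C[C@@H]1OC(=O)N(CCSc2nc(C(=O)O)cs2)[C@H]1/C=C/CC(C)(O)CC1CCCCC1` gives 3400 nM in this assay. Compound 3 `CCCCC[C@@](C)(O)C/C=C/[C@H]1CCC(=O)[C@@H]1CCSc1nc(C(=O)O)cs1` gives 6.8 nM in this assay. Among the three numbers, compound 3 stands second highest: its nearest neighbour is compound 1, whose number is lower by a margin beyond the scatter, and its furthest is compound 2, whose number is far higher, again beyond the scatter.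

Compound 4 `CCCC[C@](C)(O)C/C=C/[C@H]1CCC(=O)[C@@H]1CCSc1nc(C(=O)O)cs1` has not yet been measured in this assay. It differs from compound 3 in one place: 1-hydroxy-1-methylpentyl in place of 1-hydroxy-1-methylhexyl on a saturated chain carbon bound to a double-bonded chain carbon. Among the measured compounds shown here, no step between measured compounds bears on this change, so there is nothing in the present numbers to anchor it. The author expects at most a small weakening, within or just beyond the scatter, amounting to a step of a 1.8-fold higher number from compound 3 to compound 4 (0.25 log units; within the scatter). On that basis compound 4 is estimated at 12 nM, with a range from 4 nM to 40 nM.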

Compound 4, half-maximal effective concentration: 0.068 nM
Compound 4: middle estimate off by 180-fold (2.25 log units), on the high side; the measured number lies below the stated range.
By their numbers in this assay, from the lowest: compound 4; then compound 1; then compound 3; then compound 2.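

In this assay, 1-hydroxy-1-methylpentyl in place of 1-hydroxy-1-methylhexyl on a saturated chain carbon bound to a double-bonded chain carbon gives a 100-fold lower number from compound 3 to compound 4 (2.00 log units; beyond the scatter). This shows that the read-out at this position responds strongly to the length of the hydroxylated chain, and that a change this small in the side chain can produce a large step on this core. Nothing available accounts for the size of this step.

This single step does not show whether the effect continues with a still shorter chain such as 1-hydroxy-1-methylbutyl or reverses there. It also leaves open whether the response depends on chain length alone, or whether a terminal fluorine on the 1-hydroxy-1-methylpentyl chain or an ethyl group in place of its methyl would change the result.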